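Chloro in Place of Methyl on a Compound at the Limit

A few compounds are considered here, and "the series" means these few. Any claim that something is new, unique, unknown or untested is made for them only; others in the source may bear on it.

Measured so far:
compound 1 `O=C([C@H]1CC2CCC1C2)N1CC(c2nc(-c3ccccc3)no2)C1` — 120 nM
compound 2 `Cc1cccc(-c2noc(C3CN(S(=O)(=O)c4cccc(C)c4)C3)n2)c1` — > 10000 nM

In an assay on HEK293 cells for positive allosteric modulation of metabotropic glutamate receptor 5 (Homo sapiens), read by FLIPR (a higher number here means that more compound is needed for the effect, a lower number that less compound is needed), compound 1 gives 120 nM. Compound 2 does not give a number at all: its result is a limit of the assay, > 10000 nM, meaning the effect was not reached within the concentrations tested, as the limit of > 10000 nM in this assay, at which 1 of the 2 values shown sits, records. Among the measured compounds shown here, with only two compounds, and one of them sitting at the limit, no single change has yet been measured.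

Compound 3 `Cc1cccc(S(=O)(=O)N2CC(c3nc(-c4cccc(Cl)c4)no3)C2)c1` is the next step from compound 2. The change is chloro in place of methyl on an aromatic carbon; in words, chloro in place of methyl on an aromatic carbon. For the measured compounds named here, no measured pair shows this change, so nothing observed here says which way it will go. Since compound 2 stands at the limit, the most likely outcome is that compound 3 also reaches no number, and the step of a number no higher from compound 2 to compound 3 (the limit leaves the size open) is expected to be none beyond the scatter. Compound 3 is estimated at 10000 nM, with a range from 2000 nM to 50000 nM.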

Compound 3, half-maximal effective concentration: > 10000 nM
Compound 3 ended at the assay's limit; the forecaster's own chance of this, stated with the estimate: 70%; the middle value sits exactly at the limit.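

Among the compounds shown here, compound 2 and compound 3 both stand at a limit of this assay rather than at a number, so no step between them can be read. The compounds shown leave open whether chloro in place of methyl on an aromatic carbon changes the effect at all, and how much of either compound would be needed to reach it.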